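Trimming the propyl chain of compound 1

The compounds below may be only part of what the source reports. "The series", "measured", "known", "first", "only" and "open" are said of these compounds alone.

Among the measured compounds shown here, compound 1 (`CCCN(c1ccc(OC)cc1)c1ncnc2occ(C)c12`) reads 40.3 nM in a functional assay on SK-OV-3 cells (Homo sapiens) for inhibition, read by sulforhodamine B assay, with a stated time of 48 h (a higher number here means a weaker inhibitor, a lower number a stronger inhibitor), and holds the higher of the two numbers so far. Compound 2 (`CSc1ccc(N(C)c2ncnc3occ(C)c23)cc1`) reads 18.6 nM in this assay and the gap between the two lies beyond the scatter. Compound 3 (`CCN(c1ccc(OC)cc1)c1ncnc2occ(C)c12`) departs from compound 1 in one place: hydrogen in place of methyl on a saturated chain carbon, two bonds along the chain from a nitrogen on an aromatic ring gives hydrogen in place of methyl on a saturated chain carbon, two bonds along the chain from a nitrogen on an aromatic ring, which reads as propyl to ethyl. For the measured compounds named here, no measured pair sizes this change. In this assay a small step towards a lower number is expected, possibly none beyond the scatter. The estimate means an expected 1.4-fold lower number from compound 1 to compound 3 (0.16 log units; within the scatter) in this series. Compound 3 is estimated at 28 nM (expected range 11 nM to 70 nM).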

Compound 3, half-maximal inhibitory concentration: 14.5 nM
For compound 3 the middle estimate is 1.9-fold (0.29 log units) above the measured one, and the stated range covers the measured number.
By their numbers in this assay, from the lowest: compounds 3 and 2 (each within the scatter of the next); then compound 1.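

Cutting the propyl chain to ethyl gives a 2.8-fold lower number from compound 1 to compound 3 (0.44 log units; beyond the scatter) in this assay, the first step in the series that isolates a single change. Compounds 1 and 2 differ in more than one place, so their gap could not be assigned to this position. The step shows that, with the rest of compound 1 held constant, the methyl on a saturated chain carbon, two bonds along the chain from a nitrogen on an aromatic ring, can be replaced by hydrogen with a lower number beyond the scatter.

The compounds shown leave open whether ethyl to methyl would extend the step with the rest of compound 3 unchanged, and how a longer chain, an isopropyl group or a chain ending in an amine would read. What lies behind the step also stays open, as no measurement bears on its cause.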